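Trading 2,6-difluorophenyl for 1H-pyrrol-2-yl on a carbonyl carbon

This account rests on a few compounds, and the source may have more. Where it says the series, first, only, none or still open, it means among the compounds named here.

Measured in a functional assay on NCI-H1650 cells (Homo sapiens) for inhibition, read by sulforhodamine B assay, with a stated time of 3 days; a higher number here means a weaker inhibitor, a lower number a stronger inhibitor:
- compound 1 `O=C1Nc2ccc(F)cc2/C1=C\C(=O)c1ccc(O)cc1F`: 3460 nM
- compound 2 `O=C1Nc2ccc(F)cc2/C1=C\C(=O)c1ccc[nH]1`: 2840 nM
- compound 3 `CN1CCN(c2cccc(N/C=C3\C(=O)Nc4ccc(NC(=O)c5c(F)cccc5F)cc43)c2)CC1`: 1630 nM

Compound 3 has the lowest of these three numbers, but the picture is a narrow one. Its gap to compound 2 lies within the scatter of repeated measurements, and its gap to compound 1 lies only just beyond it.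

The next molecule, compound 4 `CN1CCN(c2cccc(N/C=C3\C(=O)Nc4ccc(NC(=O)c5ccc[nH]5)cc43)c2)CC1`, differs from compound 3 in one place: 1H-pyrrol-2-yl in place of 2,6-difluorophenyl on a carbonyl carbon. In words, 1H-pyrrol-2-yl stands in place of 2,6-difluorophenyl on a carbonyl carbon.

Among the measured compounds shown here, no two measured compounds differ in one place only, so the data give no direct measure of this change. The nearest hint is compound 2, which also carries 1H-pyrrol-2-yl on a carbonyl carbon and gives 2840 nM in this assay. The rest of its structure is different, so it is only a loose guide. With so little to go on, no step beyond the scatter is expected, in either direction. The expected result is a 1.1-fold higher number from compound 3 to compound 4 (0.04 log units; within the scatter), an estimated step within the scatter. For compound 4 the estimated value is 1800 nM, with an expected range of 600 nM to 5000 nM.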

Compound 4, half-maximal inhibitory concentration: 7560 nM
The estimate for compound 4 lay 4.2-fold (0.62 log units) below the measured number; measured number above the stated range.
By their numbers in this assay, from the lowest: compounds 3, 2 and 1 (each within the scatter of the next, the first and the last beyond it); then compound 4.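

Among the compounds shown here, compounds 3 and 4 differ only in the group on this carbonyl carbon, so they form the first pair that measures the change directly. In this assay, replacing 2,6-difluorophenyl with 1H-pyrrol-2-yl gives a 4.6-fold higher number from compound 3 to compound 4 (0.67 log units; beyond the scatter), a modest step but one beyond the usual scatter, which shows that the group at this position can change the result in this series. The swap alters several things at once, as a six-membered carbon ring with two fluorines gives way to a five-membered ring with one nitrogen and a hydrogen-bond donor, and no measurement available here explains the step.

The two compounds leave open which part of the swap matters, and a plain phenyl or a 1-methyl-1H-pyrrol-2-yl group on the same carbonyl carbon would begin to pull those parts apart. As far as these compounds go, it is also open whether the same swap would give a similar step on a different shared core, or with something other than the methylpiperazine, such as a morpholine, on the far side of the molecule.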